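Expected Cytotoxicity of a Butylurea Replacing a Methoxybenzamide

The source may hold more compounds than are shown below. What is called first, only, known or untested is meant among the compounds shown, and "the series" means these compounds.

Of the compounds shown here, three sharing one core have been tested in an ADME assay on Vero cells (Chlorocebus sabaeus) for cytotoxicity, read by resazurin assay, with a stated time of 3 days; a lower number here means a stronger inhibitor, a higher number a weaker inhibitor. Compound 1 `COc1ccc(C(=O)Nc2cc3nc(C4CCCCC4)[nH]c3cc2N(C)C)cc1` gives > 100 ug/mL, which is a limit of the assay rather than a number. Compound 2 `CCN(CC)c1cc2[nH]c(C3CCCCC3)nc2cc1NC(=O)OCC(F)(F)F` gives > 100 ug/mL, again a limit. Compound 3 `COc1ccc(C(=O)Nc2cc3nc(C4CCCCC4)[nH]c3cc2N2CCCC2)cc1` gives > 100 ug/mL, also a limit. The step that the two limits leave unreadable from compound 1 to compound 3 therefore cannot be sized, because the limit of > 100 ug/mL in this assay, at which 3 of the 3 values shown sit, holds all three values. Compound 4 `CCCCNC(=O)Nc1cc2nc(C3CCCCC3)[nH]c2cc1N1CCCC1` differs from compound 3 by butylamino in place of 4-methoxyphenyl on a carbonyl carbon. Among the compounds with values here, no measured step bears on this change; every value sits at the limit. Compound 3 stands at that limit together with the other two values shown. Over a number no higher from compound 3 to compound 4 (the limit leaves the size open) no step beyond the scatter is expected. Compound 4 is therefore estimated at 100 ug/mL, with a range from 50 ug/mL to 200 ug/mL.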

Compound 4, half-maximal inhibitory concentration: > 100 ug/mL
Compound 4: a limit, no number (the forecaster's own chance of this, stated with the estimate: 85%); the middle value sits exactly at the limit.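

No step can be read between compound 3 and compound 4, because both stand at the same limit rather than at a number: the limit of > 100 ug/mL in this assay, at which 4 of the 4 values shown sit.

The compounds shown leave open at what concentration, if any, each would become toxic to the cells.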